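Anilino for cyclohexylamino on the shared core, cinnamamide series

The compounds below may be only part of what the source reports. "The series", "measured", "known", "first", "only" and "open" are said of these compounds alone.

Two compounds in this series have numbers. Compound 1 `Nc1ccccc1NC(=O)c1ccc(Cn2cnc3c(Nc4ccccc4)nc(Cl)nc32)cc1` gives 74.8% in a functional assay on HepG2 cells (Homo sapiens) for antiproliferative activity, read by CCK-8 assay, with a stated time of 72 h, tested at 8 uM; a lower number here means a weaker effect, a higher number a stronger effect of the compound at the concentration tested. Compound 2 `Nc1ccccc1NC(=O)/C=C/c1ccc(Cn2cnc3c(NC4CCCCC4)nc(Cl)nc32)cc1` gives 42.7% in this assay, the lower of the two numbers, and it sits well below compound 1 by a gap beyond the usual scatter. Compound 1 differs from compound 2 in more than one place, so nothing beyond the two numbers themselves can be read from that pair.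

Compound 3 `Nc1ccccc1NC(=O)/C=C/c1ccc(Cn2cnc3c(Nc4ccccc4)nc(Cl)nc32)cc1` is not yet measured. It differs from compound 2 in one place (phenyl in place of cyclohexyl on a nitrogen on an aromatic ring). Among the measured compounds shown here, compound 1 already carries the anilino group and stands high, which is the only hint available on what this group does on the shared core; no single-point step between measured compounds exists to size it.

The expectation for compound 3 is therefore an upward step in this assay, estimated at a number 19.3 percentage points higher from compound 2 to compound 3 (beyond the scatter), beyond the scatter but not reaching compound 1. Compound 3 is estimated at 62%, with a range from 46% to 78%.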

Compound 3, a percentage reported as inhibition, at one concentration (the size of the read-out at that concentration, not a potency): 41.9%
Compound 3: the middle estimate sits 20.1 percentage points above what was measured; the measured number lies below the stated range.
By their numbers in this assay, from the lowest: compounds 3 and 2 (each within the scatter of the next); then compound 1.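

In this assay, phenyl in place of cyclohexyl on a nitrogen on an aromatic ring gives a number 0.8 percentage points lower from compound 2 to compound 3 (within the scatter), so on this shared core with the cinnamamide side chain, the cyclohexylamino and anilino groups cannot be told apart. Among the compounds shown here, the high number of compound 1 therefore cannot be credited to the anilino group alone: with anilino held constant, 2-((2-aminophenyl)carbamoyl)ethenyl in place of (2-aminophenyl)carbamoyl on an aromatic carbon gives a number 32.9 percentage points lower from compound 1 to compound 3 (beyond the scatter), which is the first sized step at that place and a large one. Nothing available explains either step.

As far as these compounds go, it remains open whether phenyl and cyclohexyl would also be indistinguishable with (2-aminophenyl)carbamoyl on the aromatic carbon, and how a methyl or benzyl group on the same nitrogen would compare. Also open, from the compounds shown here alone, is whether a saturated two-carbon link or a longer butadienyl link at the aromatic carbon would stand nearer compound 1 or compound 3, and whether these steps would hold at other concentrations, since a single-concentration read-out gives no potency.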